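A dimethoxy counterpart of compound 2

The source may hold more compounds than are shown below. What is called first, only, known or untested is meant among the compounds shown, and "the series" means these compounds.

In a functional assay on HL-60 cells (Homo sapiens) for inhibition, read by CCK-8 assay, with a stated time of 48 h (on this read-out lower numbers stand for stronger inhibition and higher numbers for weaker inhibition), compound 2 (`O=C(Nc1cccc([N+](=O)[O-])c1)N1CCN(S(=O)(=O)c2sccc2-c2ccccc2Oc2ccc(O)c(O)c2)CC1`) gives 4500 nM. Compound 3 (`COc1ccc(Oc2ccccc2-c2ccsc2S(=O)(=O)NCCNC(=S)Nc2cc(C(F)(F)F)cc(C(F)(F)F)c2)cc1OC`) gives 2800 nM, and these two numbers lie within the scatter of each other. Compound 1 (`COc1ccc(Oc2ccccc2-c2ccsc2S(=O)(=O)N2CCN(C(=S)Nc3ccc([N+](=O)[O-])cc3)CC2)cc1OC`) reports only a limit, > 50000 nM.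

Compound 4 (`COc1ccc(Oc2ccccc2-c2ccsc2S(=O)(=O)N2CCN(C(=O)Nc3cccc([N+](=O)[O-])c3)CC2)cc1OC`) departs from compound 2 in one place, on an oxygen on an aromatic ring, where 3,4-dimethoxyphenyl stands in place of 3,4-dihydroxyphenyl: 3,4-dimethoxyphenyl in place of 3,4-dihydroxyphenyl on an oxygen on an aromatic ring. Among the compounds with values here, no measured pair isolates this change, so the expectation rests on loose comparisons. Compound 1 and compound 3 both carry the 3,4-dimethoxyphenyl group, but each also differs from compound 4 elsewhere. Compound 1 leans towards weaker inhibition with its limit of > 50000 nM. Compound 3 goes against that lean with 2800 nM. A moderate step towards a higher number in this assay is therefore expected, and the estimated step is a 2.0-fold higher number from compound 2 to compound 4 (0.30 log units; within the scatter). For compound 4 the estimated value is 9000 nM, with an expected range from 2500 nM to 35000 nM.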

Compound 4, half-maximal inhibitory concentration: > 50000 nM
Compound 4 was reported as a limit; the forecaster's own chance of this, stated with the estimate: 15%; at least 5.5-fold (0.74 log units) between middle value and limit.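

In this assay, the change from 3,4-dihydroxyphenyl to 3,4-dimethoxyphenyl on an oxygen on an aromatic ring now stands alone in one pair, and it gives an at least 11-fold higher number from compound 2 to compound 4 (1.04 log units; beyond the scatter). Compound 1 and compound 3 both carried the 3,4-dimethoxyphenyl group but differed from compound 4 elsewhere as well, so neither could show what this change does by itself against the core of compound 2. The true size of the step stays unknown at its upper end because compound 4 is reported only as a limit: the limit of > 50000 nM in this assay, at which 2 of the 4 values shown sit.

The step between compound 1 and compound 4 cannot be read, as both are limits. Also open, from the compounds shown here alone, is how a phenyl carrying a single hydroxyl, or an amine in place of the hydroxyl groups, would read at this position.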